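Chloropyrimidinyl amide expected to restore potency in the series

The source may hold more compounds than are shown below. What is called first, only, known or untested is meant among the compounds shown, and "the series" means these compounds.

Measured so far:
Compound 1 `Cc1nc(S(C)(=O)=O)ccc1Oc1ncnc(OC2CCN(C(=O)OC3COC3)CC2)c1F` — 326 nM
Compound 2 `CCc1cnc(C(=O)N2CCC(Oc3ncnc(Oc4ccc(S(C)(=O)=O)nc4C)c3F)CC2)nc1` — 4.7 nM

Of the two measured compounds, compound 1 gives the highest number in a functional assay on isolated protein for inhibition of Glucose-dependent insulinotropic receptor (Homo sapiens), read by HTRF and cAMP accumulation (on this read-out lower numbers stand for an effect already at smaller amounts and higher numbers for an effect only at larger amounts of compound), with compound 2 standing nearest at a 69-fold lower number from compound 1 to compound 2 (1.84 log units; beyond the scatter). Compound 3 `Cc1nc(S(C)(=O)=O)ccc1Oc1ncnc(OC2CCN(C(=O)c3ncc(Cl)cn3)CC2)c1F` is not yet measured. Its difference from compound 1 is 5-chloropyrimidin-2-yl in place of (oxetan-3-yl)oxy on a carbonyl carbon.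

Within the data shown here, the one measured step bearing on this change is the one from compound 1 to compound 2, a 69-fold lower number from compound 1 to compound 2 (1.84 log units; beyond the scatter), where the same (oxetan-3-yl)oxy group on the carbonyl carbon was replaced by a closely related substituted pyrimidinyl group. That step was large and well beyond the scatter. The change to compound 3 puts a 5-chloropyrimidin-2-yl group in the same place, so a large step in the same direction, towards a lower number in this assay, is expected, its size judged by the step from compound 1 to compound 2.

Compound 3 is therefore estimated to give 7 nM in this assay, with a range from 2.5 nM to 25 nM, an expected step of a 47-fold lower number from compound 1 to compound 3 (1.67 log units; beyond the scatter).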

Compound 3, half-maximal effective concentration: 6.12 nM
Compound 3: middle estimate off by 1.1-fold (0.06 log units), on the high side, and the stated range covers the measured number.
By their numbers in this assay, from the lowest: compounds 2 and 3 (each within the scatter of the next); then compound 1.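

In this assay, a second aromatic group can now be set against (oxetan-3-yl)oxy on the carbonyl carbon: 5-chloropyrimidin-2-yl in that place goes with a 53-fold lower number from compound 1 to compound 3 (1.73 log units; beyond the scatter), a large step in the same direction as a 69-fold lower number from compound 1 to compound 2 (1.84 log units; beyond the scatter). The large step at this place therefore does not rest on the 5-ethylpyrimidin-2-yl group alone, since it appears with both substituted pyrimidinyl groups. With the rest of the structure kept, chloro in place of ethyl on an aromatic carbon gives a 1.3-fold higher number from compound 2 to compound 3 (0.11 log units; within the scatter), which lies within the scatter, so this assay does not tell these two substituents apart.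

Nothing among the available data accounts for either large step or for the lack of a difference between chloro and ethyl. The compounds shown leave open whether the pyrimidinyl ring itself is needed on the carbonyl carbon or whether a phenyl or a pyridinyl group would serve there, and whether a methoxy group, a nitrile or an unsubstituted ring carbon in the place of chloro or ethyl would stay level with these two.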